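This account rests on a few compounds, and the source may have more. Where it says the series, first, only, none or still open, it means among the compounds named here.

Compound 1 `CCCCc1cc(C(C)=O)c(O)cc1OCCCCC#N` gives 13% in an assay on isolated protein for binding affinity to leukotriene B4 receptor 1 (Homo sapiens), tested at 1 uM (on this read-out lower numbers stand for less inhibition and higher numbers for more inhibition at the one concentration tested (going by the name of the read-out)), the lowest of the three numbers in hand. Compound 2 `CCc1cc(C(C)=O)c(O)cc1OCCCCCCC#N` gives 73% and compound 3 `CSCc1cc(C(C)=O)c(O)cc1OCCCCCCC#N` gives 64%, but each of them differs from compound 1 in more than one place, so those gaps cannot be tied to a single change. Going by the values given here, the one single-place step known, a number 9 percentage points lower from compound 2 to compound 3 (within the scatter), concerns a different change and stays within the scatter. Compound 4 `CC(=O)c1cc(CC(C)O)c(OCCCCC#N)cc1O` differs from compound 1 by 1-hydroxyethyl in place of propyl on a saturated chain carbon bound to an aromatic carbon. Among the compounds with values here, no measured step bears on this change, so no step beyond the scatter is expected in this assay. Compound 4 is therefore expected to give about 15%, within 0% to 40%. This estimate means a number 2 percentage points higher from compound 1 to compound 4 (within the scatter), a step expected to stay within the scatter.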

Compound 4, a percentage reported as inhibition, at one concentration (the size of the read-out at that concentration, not a potency): 6%
For compound 4 the middle estimate is 9 percentage points above the measured one; low and high end bracket the measured number.
By their numbers in this assay, from the lowest: compounds 4 and 1 (each within the scatter of the next); then compounds 3 and 2 (each within the scatter of the next).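

Going by these compounds alone, putting 1-hydroxyethyl in place of propyl on a saturated chain carbon bound to an aromatic carbon gives a number 7 percentage points lower from compound 1 to compound 4 (within the scatter), the first single-place reading at this position in this assay. The entering group carries a hydrogen-bond donor and acceptor that propyl lacks, yet the step stays within the scatter. Nothing measured here offers an explanation for this result.

On these data alone, whether the same swap would also stay within the scatter on compound 2, which gives 73%, remains open. So does the outcome with an amine or a carboxylic acid at this place.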